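A few compounds are considered here, and "the series" means these few. Any claim that something is new, unique, unknown or untested is made for them only; others in the source may bear on it.

Measured so far in an ADME assay on HepG2 cells (Homo sapiens) for cytotoxicity; a higher number here means that more compound is needed for the effect, a lower number that less compound is needed:
- Compound 1 `Cc1ccc(S(=O)(=O)N[C@@H](CC(=O)NC(C)(C)C)C(=O)NCCNC(=O)c2ccccc2)cc1`: > 11000 nM, a limit
- Compound 2 `Cc1ccc(S(=O)(=O)N[C@@H](CC(=O)NC(C)(C)C)C(=O)NCCNC(=O)c2ccccc2F)cc1`: > 11000 nM, a limit
- Compound 3 `Cc1ccc(S(=O)(=O)N[C@@H](CC(=O)NC(C)(C)C)C(=O)NCCNC(=O)NCc2ccccc2)cc1`: > 11000 nM, a limit

Compound 3 has no number, only the limit > 11000 nM. The series as a whole sits at one mark: the limit of > 11000 nM in this assay, at which 3 of the 3 values shown sit.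

Compound 4 `Cc1ccc(S(=O)(=O)N[C@@H](CC(=O)NC(C)(C)C)C(=O)NCCNC(=O)c2ccc(F)c(F)c2)cc1` differs from compound 3 in one place, with 3,4-difluorophenyl in place of benzylamino on a carbonyl carbon.

Among the measured compounds shown here, three measured steps bear on this change. The exchange between phenyl and benzylamino appears as a step that the two limits leave unreadable from compound 1 to compound 3, the exchange between 2-fluorophenyl and benzylamino as a step that the two limits leave unreadable from compound 2 to compound 3, and fluoro in place of hydrogen as a step that the two limits leave unreadable from compound 1 to compound 2. None of them has a readable size, but none of these changes brought any compound to a number in this assay.

No step beyond the scatter is therefore expected, in either direction. The expected step is a step that the limit leaves unreadable from compound 3 to compound 4. The estimate for compound 4 is 15000 nM, with an expected range from 8000 nM to 30000 nM, and most likely only a limit will be reported.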

Compound 4, half-maximal effective concentration: > 11000 nM
Compound 4 gave a limit, no number; the forecaster's own chance of this, stated with the estimate: 85%; the middle value is on the limit's open side.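

In this assay, among the compounds shown here, compound 4 gives > 11000 nM, a limit and not a number, so no step from compound 1, compound 2 or compound 3 to compound 4 can be read. The compounds shown leave open how much of each is needed for the effect in this assay, and whether the four differ at all.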